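The source may hold more compounds than are shown below. What is called first, only, known or untested is meant among the compounds shown, and "the series" means these compounds.

Measured so far in an ADME assay on BaF3 cells (Mus musculus) for antiproliferative activity, read by CellTiter-Glo and CCK-8 assay, with a stated time of 72 h; a lower number here means a stronger inhibitor of growth, a higher number a weaker inhibitor of growth:
Compound 1 `CNc1nc(Nc2ccc(C)c([N+](=O)[O-])c2)ncc1C(=O)Nc1cc(NC(=O)c2cccc(C(F)(F)F)c2)ccc1C` gives > 10000 nM, a limit of the assay rather than a number.
Compound 2 `Cc1ccc(NC(=O)c2cccc(C(F)(F)F)c2)cc1NC(=O)c1cnc(Nc2ccc(C)c([N+](=O)[O-])c2)nc1N(C)C` gives > 10000 nM, likewise a limit.
Compound 3 `CNc1nc(Nc2ccc(C)c(N)c2)ncc1C(=O)Nc1cc(NC(=O)c2cccc(C(F)(F)F)c2)ccc1C` gives > 10000 nM, again a limit.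

All three values sit at the limit of > 10000 nM in this assay, at which 3 of the 3 values shown sit, so compound 1 stands at the limit of this assay with no number of its own, and the two compounds next to it stand there too. The two steps that have been measured, a step that the two limits leave unreadable from compound 1 to compound 2 and a step that the two limits leave unreadable from compound 1 to compound 3, therefore cannot be read for size or direction: both start and end at the limit.

Compound 4 `CNc1nc(Nc2ccc(C)c([N+](=O)[O-])c2)ncc1C(=O)Nc1cc(NC(=O)c2ccccc2OC)ccc1C` has not yet been measured. It differs from compound 1 by 2-methoxyphenyl in place of 3-(trifluoromethyl)phenyl on a carbonyl carbon. Neither of the measured steps changes this part of the molecule, and neither gave a readable size, so they offer no guide to how large a change in this assay to expect, nor in which direction. Because compound 1 sits at the limit of > 10000 nM in this assay, at which 3 of the 3 values shown sit, compound 4 is expected to be found at that limit as well, and the estimated step of a number no higher from compound 1 to compound 4 (the limit leaves the size open) is expected to amount to no readable change. Compound 4 is thus estimated at 10000 nM, within 3000 nM to 30000 nM, and most likely reported only as a limit.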

Compound 4, concentration for 50% growth inhibition: > 10000 nM
Compound 4 was reported as a limit (the forecaster's own chance of this, stated with the estimate: 85%); the middle value lies on the limit itself.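

In this assay compound 4 gives > 10000 nM as a limit of the assay and not a number. No size or direction can be read for the step between compound 1 and compound 4, since both stand at the same limit: the limit of > 10000 nM in this assay, at which 4 of the 4 values shown sit. The compounds shown leave open which change to the shared core, if any, would give a measurable value in this assay.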